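The source may hold more compounds than are shown below. What is called first, only, known or untested is meant among the compounds shown, and "the series" means these compounds.

Measured compounds:
- Compound 1 `CC(C)CNc1nnc(SCC(=O)N(Cc2cccc([N+](=O)[O-])c2)c2ccc(F)cc2)s1`: 43.2%
- Compound 2 `C=CCNc1nnc(SCC(=O)N(Cc2cccc([N+](=O)[O-])c2)c2ccc(F)cc2)s1`: 56.5%

In an assay on isolated protein for inhibition of Amine oxidase [flavin-containing] A (Homo sapiens), read by fluorescence and Amplex Red, with a stated time of 30 min, tested at 1 uM (a lower number here means a weaker effect, a higher number a stronger effect of the compound at the concentration tested), compound 2 gives the higher of the two numbers, and its nearest neighbour is compound 1, lower by a number 13.3 percentage points higher from compound 1 to compound 2 (beyond the scatter). Compound 3 `CCNc1nnc(SCC(=O)N(Cc2cccc([N+](=O)[O-])c2)c2ccc(F)cc2)s1` differs from compound 2 in one place: methyl in place of vinyl on a saturated chain carbon bound to a nitrogen on an aromatic ring. Within the data shown here, the only measured step that bears on this change is a number 13.3 percentage points higher from compound 1 to compound 2 (beyond the scatter), where a smaller group on the same saturated chain carbon bound to a nitrogen on the aromatic ring went with a modestly higher number. Among the measured compounds shown here, the present change again makes the group smaller, but it also removes the one double bond outside aromatic rings, and no measured pair shows what that removal does. The expected step is therefore small, a number 6.5 percentage points lower from compound 2 to compound 3 (within the scatter), probably within the scatter. For compound 3 the estimate in this assay is 50%, with a likely range from 35% to 65%.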

Compound 3, a percentage reported as inhibition, at one concentration (the size of the read-out at that concentration, not a potency): 61.9%
For compound 3 the middle estimate is 11.9 percentage points below the measured one; low and high end bracket the measured number.
By their numbers in this assay, from the lowest: compound 1; then compounds 2 and 3 (each within the scatter of the next).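

In this assay the ethylamino compound adds a result of a number 5.4 percentage points higher from compound 2 to compound 3 (within the scatter) for this saturated chain carbon bound to a nitrogen on an aromatic ring, so the double bond of the allyl group is not required to keep the read-out at this level, and vinyl and methyl cannot be told apart here. The step of a number 18.7 percentage points higher from compound 1 to compound 3 (beyond the scatter) places compound 1, with its isopropyl group on that carbon, apart from both compound 2 and compound 3. Nothing available explains these differences.

As far as these compounds go, it remains open what a free amino group, a methylamino group, a longer chain such as n-butyl or a small ring such as cyclopropyl would give at this place. Nor do these compounds show what a nitrile in place of the nitro group would do.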